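This account rests on a few compounds, and the source may have more. Where it says the series, first, only, none or still open, it means among the compounds named here.

Compound 1 `O=C(Nc1cccc(F)c1)c1cc(=O)[nH]c2cc(Br)ccc12`: 8900 nM
Compound 2 `O=C(Nc1cccc(F)c1)c1cc(=O)[nH]c2cc(-c3ccccc3)ccc12`: > 20000 nM
Compound 3 `CC(C)(C)c1ccc(-c2ccc3c(C(=O)Nc4cccc(F)c4)cc(=O)[nH]c3c2)cc1`: not yet measured

The values are from a functional assay on KYSE-70 cells for antiproliferative activity against KYSE-70 cell line (Homo sapiens), read by MTT assay, with a stated time of 72 h; on this read-out higher numbers stand for weaker inhibition and lower numbers for stronger inhibition. For compound 2, the reading of > 20000 nM is a limit of the assay and not a number.

Compound 3 has tert-butyl in place of hydrogen on an aromatic carbon, turning phenyl into 4-(tert-butyl)phenyl: tert-butyl in place of hydrogen on an aromatic carbon.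

Within the data shown here, the only measured step is a different change, phenyl in place of bromo on an aromatic carbon: an at least 2.2-fold higher number from compound 1 to compound 2 (0.35 log units; beyond the scatter). Among the measured compounds shown here, with compound 2 at its limit and that step as the sole guide, no step beyond the scatter is expected in this assay.

The expected step is a number no higher from compound 2 to compound 3 (the limit leaves the size open).

Compound 3 is estimated at 20000 nM, with an expected range of 7000 nM to 50000 nM.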

Compound 3, half-maximal inhibitory concentration: > 20000 nM
Compound 3 was reported as a limit; the forecaster's own chance of this, stated with the estimate: 60%; the middle value lies on the limit itself.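

In this assay, a second aryl group at the bromo position, now carrying tert-butyl, again gives no readable potency, and 4-(tert-butyl)phenyl in place of bromo gives an at least 2.2-fold higher number from compound 1 to compound 3 (0.35 log units; beyond the scatter). For compound 3, the reading of > 20000 nM is a limit of the assay and not a number. The step from compound 2 to compound 3 cannot be read because both compounds sit at that limit: the limit of > 20000 nM in this assay, at which 2 of the 3 values shown sit.

Going by these compounds, whether an amine or a carboxylic acid on the phenyl would bring a reading inside the assay's range stays open. So does the effect of a methoxy group or a short alkyl chain in place of bromo.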